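The source may hold more compounds than are shown below. What is called first, only, known or untested is meant among the compounds shown, and "the series" means these compounds.

The measured compounds:
compound 1, `CCOC(=O)C(=O)C(CC)NC(=O)C(CC(C)C)NC(=O)OCc1ccccc1`, in an assay on isolated protein (Oryctolagus cuniculus) for inhibition of Calpain-2 catalytic subunit (Homo sapiens), at pH 8.0; a lower number here means a stronger inhibitor, a higher number a weaker inhibitor: 400 nM
compound 2, `CCCCCCCNC(=O)C(=O)C(CC)NC(=O)C(CC(C)C)NC(=O)OCc1ccccc1`, in this assay: 67 nM

Compound 2 stands lowest of the two numbers in this assay. Going by the values given here, the only other number is that of compound 1, 400 nM. The step between the two is a 6.0-fold lower number from compound 1 to compound 2 (0.78 log units; beyond the scatter), beyond the scatter. Compound 3, `CCCCCCCCNC(=O)C(=O)C(CC)NC(=O)C(CC(C)C)NC(=O)OCc1ccccc1`, carries one further change: methyl in place of hydrogen on a saturated chain carbon, seven bonds along the chain from an amide-type nitrogen. Among the compounds with values here, the single measured step bears on compound 3 only loosely, since it exchanged ethoxy for heptylamino on a carbonyl carbon, a 6.0-fold lower number from compound 1 to compound 2 (0.78 log units; beyond the scatter), whereas the change to compound 3 adds a single carbon to the saturated chain and keeps the amide-type nitrogen. Within the data shown here, no measured pair differs by one chain carbon, so the expectation rests on the small size of the change. For compound 3 a step of about a 1.2-fold lower number from compound 2 to compound 3 (0.09 log units; within the scatter) is expected, within the scatter. The estimate for compound 3 is 55 nM, with a range from 25 nM to 130 nM.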

Compound 3, inhibition constant: 19 nM
Estimate against measurement, compound 3: 2.9-fold (0.46 log units) above, and the stated range ends above it.
By their numbers in this assay, from the lowest: compound 3; then compound 2; then compound 1.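

Adding one carbon at this place is not a negligible change: methyl in place of hydrogen on a saturated chain carbon, seven bonds along the chain from an amide-type nitrogen, gives (a 3.5-fold lower number from compound 2 to compound 3 (0.55 log units; beyond the scatter)) in this assay. The earlier step changed ethoxy to heptylamino in one exchange, whereas this pair keeps the amide-type nitrogen and shows that chain length alone moves the number, and the two changes taken together now amount to (a 21-fold lower number from compound 1 to compound 3 (1.32 log units; beyond the scatter)). No evidence is at hand to explain why the added carbon counts for this much.

As far as these compounds go, two amine chains differing by one carbon do not establish a trend, so it remains open whether a longer chain such as nonyl or decyl would lower the number further or raise it again. Also open, from the compounds shown here alone, is how a chain ending in a phenyl ring or a carboxylic acid would compare with octylamino.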